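Benzyl for butoxy on the aniline ring of compound 2

The source may hold more compounds than are shown below. What is called first, only, known or untested is meant among the compounds shown, and "the series" means these compounds.

Compound 1, `O/N=C(/Nc1cccc(Cl)c1)c1ccc2occc2c1`, and compound 2, `CCCCOc1cccc(N/C(=N/O)c2ccc3occc3c2)c1`, share a core and differ only in the group on the aniline ring. In an assay on tissue (HeLa cells) for inhibition of Indoleamine 2,3-dioxygenase 1 (Homo sapiens), read by spectrophotometry (a higher number here means a weaker inhibitor, a lower number a stronger inhibitor), compound 1 gives 1500 nM. For compound 2 this assay records only the limit > 30000 nM, so compound 2 stands at the limit of the assay and no number is known for it. The step from chloro to butoxy, an at least 20-fold higher number from compound 1 to compound 2 (1.30 log units; beyond the scatter), was large, and that limit is noted as the limit of > 30000 nM in this assay, at which 1 of the 2 values shown sits. Compound 3, `O/N=C(/Nc1cccc(Cc2ccccc2)c1)c1ccc2occc2c1`, keeps the core and carries the change (benzyl in place of butoxy on an aromatic carbon). Among the measured compounds shown here, the one measured step shows that a bulky group at this place weakened binding strongly, and benzyl is also a large group, so compound 3 is expected to remain a weak inhibitor. The expected step is an at least 2.0-fold lower number from compound 2 to compound 3 (0.30 log units; that floor lies within the scatter). Compound 3 is estimated at 15000 nM, between 3000 nM and 60000 nM.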

Compound 3, half-maximal inhibitory concentration: > 30000 nM
Compound 3: no number, only a limit; the forecaster's own chance of this, stated with the estimate: 45%; middle value at least 2.0-fold (0.30 log units) from the limit.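

Compound 3 shows that the loss at this place on the aniline ring is not particular to butoxy: in this assay, the change from chloro to benzyl gives an at least 20-fold higher number from compound 1 to compound 3 (1.30 log units; beyond the scatter). Butoxy, a chain with an oxygen, and benzyl, an all-carbon aromatic ring, therefore lead to the same outcome, so the oxygen of butoxy is not needed for the loss. Compound 3 records only a limit, > 30000 nM, and the step from compound 2 to compound 3 cannot be read, with both compounds at the same limit: the limit of > 30000 nM in this assay, at which 2 of the 3 values shown sit.

Still open, as far as these compounds go, is how other groups at this place, such as fluoro, methoxy, an amine or a carboxylic acid, compare with the chloro of compound 1. Any real difference between butoxy and benzyl also remains unknown.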